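The compounds below may be only part of what the source reports. "The series", "measured", "known", "first", "only" and "open" are said of these compounds alone.

Compound 1, `COc1ccc(NC(=O)CN2CCN(S(=O)(=O)N3CCC(C)CC3)CC2)cc1`, is known in an assay on HEK293 cells for activation of potassium channel subfamily T member 1 (Homo sapiens), read by thallium flux (on this read-out lower numbers stand for an effect already at smaller amounts and higher numbers for an effect only at larger amounts of compound), only by a limit: in this assay compound 1 gives > 10000 nM, which is the limit of the measurement and not a number. The limit, (the limit of > 10000 nM in this assay, at which 1 of the 2 values shown sits), leaves open how far compound 1 really lies from an effect. For the measured compounds named here, a second compound, compound 2 with the structure `COc1ccc(Cl)cc1NC(=O)CC1CCN(S(=O)(=O)N2CCC(C)CC2)CC1`, shares the sulfonyl-piperidine part but differs from compound 1 in more than one place, so no single step connects the two; in this assay compound 2 gives 9300 nM.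

The compound not yet measured is compound 3, `CC1CCN(S(=O)(=O)N2CCN(CC(=O)Nc3cc(Cl)ccc3F)CC2)CC1`. It differs from compound 1 by 5-chloro-2-fluorophenyl in place of 4-methoxyphenyl on an amide-type nitrogen, a 5-chloro-2-fluorophenyl in place of the 4-methoxyphenyl on the amide-type nitrogen. Going by the values given here, no measured pair shows this exchange, and compound 1 gives only a limit, so the expectation rests on little. The step from compound 1 to compound 3 is expected to be an at least 1.6-fold lower number from compound 1 to compound 3 (0.22 log units; that floor lies within the scatter), in the direction of an effect at smaller amounts, but it may not reach beyond the scatter. Compound 3 is therefore estimated at 6000 nM, between 2000 nM and 20000 nM.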

Compound 3, half-maximal effective concentration: 3800 nM
For compound 3 the middle estimate is 1.6-fold (0.20 log units) above the measured one; measured number inside the range.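

In this assay, the exchange of 4-methoxyphenyl for 5-chloro-2-fluorophenyl on the amide-type nitrogen gives an at least 2.6-fold lower number from compound 1 to compound 3 (0.42 log units; beyond the scatter). This is the first step shown that changes one place only, and it shows that the group on this nitrogen can move the read-out towards an effect at smaller amounts, with the rest of the core of compound 1 unchanged and compound 3 at 3800 nM. The size of the step remains a floor and not a measured difference, because the value of compound 1 is a limit of the assay and not a number: the limit of > 10000 nM in this assay, at which 1 of the 3 values shown sits.

The compounds shown leave open whether the step comes from the chlorine, the fluorine or the two together, since no phenyl carrying only one of them appears here, and whether the loss of the methoxy group itself plays any part. They also leave open how other groups on this phenyl ring, such as a trifluoromethyl or a nitrile, would read in this assay, and whether the same exchange would give a similar step on a different core.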